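From 2-ethoxyethyl to 4-chlorobenzyl, starting at a limit

A few compounds are considered here, and "the series" means these few. Any claim that something is new, unique, unknown or untested is made for them only; others in the source may bear on it.

In a functional assay on RAW264.7 cells (Mus musculus) for inhibition, read by Griess assay, with stated times of 1 h and 24 h (on this read-out higher numbers stand for weaker inhibition and lower numbers for stronger inhibition), compound 3 (`CCOCCOc1ccc(C(O)C2OC(=O)c3c(OC)cc(OC)cc32)cc1`) gives only a limit and not a number (> 10000 nM). Compound 1 (`COCCOc1ccc(C(O)C2OC(=O)c3c(OC)cc(OC)cc32)cc1`) also gives only a limit (> 10000 nM). Among the measured compounds shown here, compound 2 (`COCCCCOc1ccc(C(O)C2OC(=O)c3c(OC)cc(OC)cc32)cc1`) gives the one true number so far (8210 nM). The series therefore rests largely on the limit of > 10000 nM in this assay, at which 2 of the 3 values shown sit, and little can be read from it.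

Compound 4 (`COc1cc(OC)c2c(c1)C(C(O)c1ccc(OCc3ccc(Cl)cc3)cc1)OC2=O`) has 4-chlorophenyl in place of ethoxymethyl on a saturated chain carbon bound to an oxygen on an aromatic ring. For the measured compounds named here, three measured steps bear on this change, all of them within the chain. With 2-methoxyethyl in place of methoxy there is an at least 1.2-fold lower number from compound 1 to compound 2 (0.08 log units; that floor lies within the scatter) and with ethoxy in place of 2-methoxyethyl there is an at least 1.2-fold higher number from compound 2 to compound 3 (0.08 log units; that floor lies within the scatter) while the third is a step that the two limits leave unreadable from compound 1 to compound 3 and cannot be sized. None of them brings in a ring, so they are only a weak guide.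

Compound 2 (8210 nM) shows that a readable value can occur with a change in this chain, so a modest move to a lower number is expected. For compound 4 another limit remains quite possible. In this assay the expected change is small to moderate (an at least 1.6-fold lower number from compound 3 to compound 4 (0.22 log units; that floor lies within the scatter)). Compound 4 is estimated at 6000 nM (expected range 1800 nM to 15000 nM).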

Compound 4, half-maximal inhibitory concentration: 4320 nM
The estimate for compound 4 lay 1.4-fold (0.14 log units) above the measured number, within the range that was stated.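

Among the compounds shown here, putting a ring at this position, on a saturated chain carbon bound to an oxygen on an aromatic ring, gives the first steps in this assay that lie beyond the scatter: 4-chlorophenyl in place of ethoxymethyl gives an at least 2.3-fold lower number from compound 3 to compound 4 (0.36 log units; beyond the scatter), and 4-chlorophenyl in place of methoxymethyl gives an at least 2.3-fold lower number from compound 1 to compound 4 (0.36 log units; beyond the scatter). Against the one chain with a true number, 3-methoxypropyl, the step reads a 1.9-fold lower number from compound 2 to compound 4 (0.28 log units; within the scatter), so the ring and that chain cannot be told apart. The two larger steps are floors rather than full sizes, and the comparison remains thin: the limit of > 10000 nM in this assay, at which 2 of the 4 values shown sit.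

Only one ring-bearing compound is shown, so it stays open whether the ring alone or the chlorine on it matters, and a plain benzyl group or a 4-methoxybenzyl group in the same place would separate the two. Going by these compounds, how a chain ending in an amine or a carboxylic acid would read in this assay is also open.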